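This account rests on a few compounds, and the source may have more. Where it says the series, first, only, none or still open, it means among the compounds named here.

Measured so far in an assay for binding affinity to dual specificity mitogen-activated protein kinase kinase 4 (Homo sapiens), read by KINOMEscan, tested at 100 nM; a higher number here means a weaker effect of the compound at the concentration tested, a lower number a stronger effect:

Compound 1, `CCCS(=O)(=O)Nc1ccc(F)c(C(=O)c2n[nH]c3ncc(-c4ccccc4C)cc23)c1F`, gives 7%.
Compound 2, `CCCS(=O)(=O)Nc1ccc(F)c(C(=O)c2n[nH]c3ncc(-c4ccc([N+](=O)[O-])cc4)cc23)c1F`, gives 4.2%.

Among the measured compounds shown here, the only step between them, a number 2.8 percentage points lower from compound 1 to compound 2 (within the scatter), lies within the scatter, so compound 2 stands within the scatter of compound 1 in this assay. Compound 3, `CCCS(=O)(=O)Nc1ccc(F)c(C(=O)c2n[nH]c3ncc(-c4ccc(C(=O)O)cc4)cc23)c1F`, differs from compound 2 at the same position: carboxy in place of nitro on an aromatic carbon. For the measured compounds named here, the one step that bears on this, a number 2.8 percentage points lower from compound 1 to compound 2 (within the scatter), swapped a group on that phenyl ring without moving the read-out beyond the scatter, so no step beyond the scatter is expected here either; the expected step is a number 1.8 percentage points higher from compound 2 to compound 3 (within the scatter). Compound 3 is therefore estimated at 6%, with a range from 1% to 20%.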

Compound 3, a percentage reported as activity, at one concentration (the size of the read-out at that concentration, not a potency): 0.1%
For compound 3 the middle estimate is 5.9 percentage points above the measured one, and the stated range ends above it.
By their numbers in this assay, from the lowest: compounds 3, 2 and 1 (each within the scatter of the next).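

Carboxy in place of nitro (a number 4.1 percentage points lower from compound 2 to compound 3 (within the scatter)) and 4-carboxyphenyl in place of 2-methylphenyl (a number 6.9 percentage points lower from compound 1 to compound 3 (within the scatter)) both leave this assay unchanged beyond the scatter. This position therefore tolerates a group carrying a hydrogen-bond donor, which neither earlier compound had, and all three compounds lie within the scatter of one another. Nothing available here explains why this is so. Still open, on these data alone, is whether an amine or a longer chain at this position would move the read-out beyond the scatter.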